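The source may hold more compounds than are shown below. What is called first, only, known or untested is meant among the compounds shown, and "the series" means these compounds.

Measured compounds:
compound 1, `COc1ccc(OC)c(/C=C/c2nnc(Nc3ccc(Cl)cc3)o2)c1`: > 100000 nM
compound 2, `COc1ccc(OC)c(/C=C/C(=O)N/N=C/c2ccc(Cl)cc2)c1`: > 100000 nM

In a functional assay on NCI-H322M cells (Homo sapiens) for antiproliferative activity, read by sulforhodamine B assay, with a stated time of 48 h (on this read-out higher numbers stand for weaker inhibition of growth and lower numbers for stronger inhibition of growth), both readings are limits of the assay rather than numbers. Compound 1 sits at the limit of > 100000 nM in this assay, at which 2 of the 2 values shown sit. Compound 2 sits at that same limit. Compound 2 therefore stands at the edge of what this assay can report, with no total growth inhibition found within the tested range.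

Compound 3, `COc1ccc(OC)c(/C=C/C(=O)N/N=C/c2ccccc2)c1`, is not yet measured. It differs from compound 2 by hydrogen in place of chloro on an aromatic carbon. Going by the values given here, no step between measured compounds is available to size this change. With compound 2 already at its limit, the step that the limit leaves unreadable from compound 2 to compound 3 is expected to be none beyond the scatter. Compound 3 is expected at about 150000 nM, in a range from 40000 nM to 600000 nM, and most likely reported again only as a limit.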

Compound 3, concentration for total growth inhibition: > 100000 nM
Compound 3: a limit, no number (the forecaster's own chance of this, stated with the estimate: 80%); the middle value is on the limit's open side.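

In this assay, compound 2 and compound 3 both give limits rather than numbers, so no step can be read for the change from 4-chlorophenyl to phenyl: the limit of > 100000 nM in this assay, at which 3 of the 3 values shown sit. The compounds shown leave open whether this change affects growth inhibition at all.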